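Chloro for bromo on the benzyl ether of a benzothiazole

This account rests on a few compounds, and the source may have more. Where it says the series, first, only, none or still open, it means among the compounds named here.

Compound 2 `Brc1ccc(COc2nc3ccccc3s2)cc1` stands highest of the two compounds measured in a functional assay on the whole organism with Mus musculus as the target, with a stated time of 1 h, at a dose of 100 mg/kg by the intraperitoneal route (on this read-out higher numbers stand for more inhibition at the one dose given (going by the name of the read-out) and lower numbers for less inhibition), where compound 2 gives 78%. Compound 1 `COc1ccc(COc2nc3ccccc3s2)cc1` gives 2.43% in this assay, and the step of a number 75.6 percentage points higher from compound 1 to compound 2 (beyond the scatter) is the only one recorded. Compound 3 `Clc1ccc(COc2nc3ccccc3s2)cc1` differs from compound 2 by chloro in place of bromo on an aromatic carbon. Among the measured compounds shown here, no measured step swaps one halogen for another, so that single step offers only loose guidance. A step within the scatter, or a modest drop, is expected: a number 13 percentage points lower from compound 2 to compound 3 (beyond the scatter). Compound 3 is therefore estimated at 65%, in a range from 35% to 88%.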

Compound 3, a percentage reported as inhibition, in the whole organism at one dose (the size of the read-out at that dose, not a potency): 82.9%
The estimate for compound 3 lay 17.9 percentage points below the measured number; low and high end bracket the measured number.
By their numbers in this assay, from the lowest: compound 1; then compounds 2 and 3 (each within the scatter of the next).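

In this assay, this position does not separate the two halogens: chloro in place of bromo gives a number 4.9 percentage points higher from compound 2 to compound 3 (within the scatter). Chloro in place of methoxy gives a number 80.5 percentage points higher from compound 1 to compound 3 (beyond the scatter), so the large step first seen with bromo recurs with a second halogen. No measured evidence bears on why the two halogens stay level or why methoxy stands apart.

Going by these compounds, what fluoro, an amine or a carboxylic acid would give at this place stays open. So does whether the two halogens stay level at any other dose.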